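Chain-Linked Acids and an Ester: Setting Up Compound 4

A few compounds are considered here, and "the series" means these few. Any claim that something is new, unique, unknown or untested is made for them only; others in the source may bear on it.

Measured compounds:
compound 1 `Cc1c(OCCCCOc2ccc(C(=O)O)cc2Cl)ccc(C(=O)CC2CCCC2)c1O`: > 10000 nM
compound 2 `Cc1cc(OCCCCOc2ccc(C(=O)CC3CCCC3)c(O)c2C)ccc1C(=O)O`: > 10000 nM
compound 3 `COC(=O)c1ccc(OCCCCOc2ccc(C(=O)CC3CCCC3)c(O)c2C)cc1`: "not determined" (no result reported)

All three share a common core, carried through a saturated four-carbon chain to a second aromatic ring. In an assay on HEK293 cells for positive allosteric modulation of metabotropic glutamate receptor 3 (Rattus norvegicus), read by thallium flux, with a stated time of 2.5 min (on this read-out lower numbers stand for an effect already at smaller amounts and higher numbers for an effect only at larger amounts of compound), compound 1 gives > 10000 nM, which is a limit of the assay and not a number. Compound 2 likewise gives only > 10000 nM in this assay, again a limit. For compound 3, the methyl ester, this assay reports "not determined" (no result reported), so it stands nowhere on the numbers shown; its place is marked by an absence. Among the measured compounds shown here, the single step between measured compounds, a step that the two limits leave unreadable from compound 1 to compound 2, is left unreadable by the two limits, so it gives no size and no direction to carry forward.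

Compound 4 `Cc1cc(C(=O)O)ccc1OCCCCOc1ccc(C(=O)CC2CCCC2)c(O)c1C` differs from compound 3 by 4-carboxy-2-methylphenyl in place of 4-(methoxycarbonyl)phenyl on an oxygen on a saturated carbon. No readable step bears on this change. What the data do offer is the limit of > 10000 nM in this assay, at which 2 of the 3 values shown sit, and that weighs on any expectation for a further acid in this series. Compound 4 is therefore expected to sit at or near that limit, with an estimated value of 10000 nM and a plausible range from 3000 nM to 30000 nM, with a high chance that only a limit is reported.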

Compound 4, half-maximal effective concentration: > 10000 nM
Compound 4 was reported as a limit (the forecaster's own chance of this, stated with the estimate: 70%); the middle value lies on the limit itself.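

In this assay compound 4 gives > 10000 nM, a limit of the assay and not a number. Compound 1 and compound 2 also stand only as limits, and neither step to compound 4 can be read. The compounds shown leave open whether any change on the second aromatic ring gives a measurable value in this assay.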